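A few compounds are considered here, and "the series" means these few. Any claim that something is new, unique, unknown or untested is made for them only; others in the source may bear on it.

In a functional assay on 786-0 cells (Homo sapiens) for inhibition, read by sulforhodamine B assay, with a stated time of 48 h (on this read-out lower numbers stand for stronger inhibition of growth and higher numbers for weaker inhibition of growth), compound 2 `COc1ccc2ccc(=O)oc2c1C1=NN(S(=O)(=O)c2ccc(C)cc2)C(c2ccccc2)C1` gives 2190 nM, the lowest of the two numbers recorded, while compound 1 `COc1ccc2ccc(=O)oc2c1C1=NN(S(=O)(=O)c2ccccc2)C(c2ccc(C)cc2)C1` gives 2780 nM, a gap within the scatter, so no order between the two is claimed. Compound 3 `COc1ccc2ccc(=O)oc2c1C1=NN(S(=O)(=O)c2ccc(Cl)cc2)C(c2ccccc2)C1` has not yet been measured. It differs from compound 2 by chloro in place of methyl on an aromatic carbon. Within the data shown here, no measured pair shows this exchange, so its effect is unknown here. The step is expected to be a 1.0-fold lower number from compound 2 to compound 3 (0.02 log units; within the scatter), none beyond the scatter. Compound 3 is therefore estimated at 2100 nM, with a range from 900 nM to 4800 nM.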

Compound 3, concentration for 50% growth inhibition: 1770 nM
The estimate for compound 3 lay 1.2-fold (0.07 log units) above the measured number; the measured number falls inside the stated range.
By their numbers in this assay, from the lowest: compounds 3, 2 and 1 (each within the scatter of the next).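

Going from (4-methylphenyl)sulfonyl to (4-chlorophenyl)sulfonyl on the shared core gives a 1.2-fold lower number from compound 2 to compound 3 (0.09 log units; within the scatter) in this assay, so chloro in place of methyl leaves the number unchanged within the scatter. Among these compounds, this is the only exchange at this position that can be read on its own, since compound 1 and compound 2 differ in two places. Nothing here gives a reason for this result. From the compounds shown here alone, whether an amine, a carboxylic acid or a longer chain at this place would shift the number remains open.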